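A few compounds are considered here, and "the series" means these few. Any claim that something is new, unique, unknown or untested is made for them only; others in the source may bear on it.

Working notes on the series. The three measured compounds share one core and differ only in the ester chain: compound 1 `CCOC(=O)CCC(=O)N1CCN(CCCOc2cc3c(Nc4ccc(F)c(Cl)c4)ncnc3cc2OC)CC1`, compound 2 `CCCCCCOC(=O)CCC(=O)N1CCN(CCCOc2cc3c(Nc4ccc(F)c(Cl)c4)ncnc3cc2OC)CC1` and compound 3 `CCCCCCCCOC(=O)CCC(=O)N1CCN(CCCOc2cc3c(Nc4ccc(F)c(Cl)c4)ncnc3cc2OC)CC1`. In a functional assay on A549 cells (Homo sapiens) for cytotoxicity, read by MTT assay, with a stated time of 24 h, tested at 60 uM (a lower number here means a stronger effect, a higher number a weaker effect of the compound at the concentration tested), compound 1 gives 61.6%, compound 2 gives 63.6% and compound 3 gives 26%, the lowest of the three numbers. The first lengthening, a number 2 percentage points higher from compound 1 to compound 2 (within the scatter), stays within the scatter, whereas a number 35.6 percentage points lower from compound 1 to compound 3 (beyond the scatter) and a number 37.6 percentage points lower from compound 2 to compound 3 (beyond the scatter) are both large and downward.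

Compound 4 `CCCCCCCCCCCOC(=O)CCC(=O)N1CCN(CCCOc2cc3c(Nc4ccc(F)c(Cl)c4)ncnc3cc2OC)CC1` carries the chain one step further: propyl in place of hydrogen on a saturated chain carbon, eight bonds along the chain from an oxygen next to a carbonyl group. Within the data shown here, the steps that bear on this are those by which compound 1 and compound 2 are lengthened into compound 3, both large and lower; the short lengthening from compound 1 to compound 2 shows that the numbers do not have to move with every added carbon. With only three points there is no way to tell whether the drop continues or levels off, so the expectation is a moderate further fall in this assay, not a large one. The step from compound 3 to compound 4 is expected as a number 8 percentage points lower from compound 3 to compound 4 (within the scatter). Compound 4 is therefore estimated at 18% in this assay, with a range from 6% to 38%.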

Compound 4, a percentage reported as activity, at one concentration (the size of the read-out at that concentration, not a potency): 3.9%
For compound 4 the middle estimate is 14.1 percentage points above the measured one; measured number outside the range, below it.
By their numbers in this assay, from the lowest: compound 4; then compound 3; then compounds 1 and 2 (each within the scatter of the next).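

In this assay the fall does not end at compound 3: adding propyl eight bonds along the chain from an oxygen next to a carbonyl group gives a number 22.1 percentage points lower from compound 3 to compound 4 (beyond the scatter) and takes the number close to the bottom of the percentage scale. The two lengthenings from compound 2 now both lower the number beyond the scatter, and compound 4 stands well apart from the shorter chains, with a number 59.7 percentage points lower from compound 2 to compound 4 (beyond the scatter) and a number 57.7 percentage points lower from compound 1 to compound 4 (beyond the scatter), although the step from compound 1 to compound 2 goes against a steady fall with every added carbon. The values come with nothing that explains the effect of the chain at this position.

Going by these compounds, whether a longer chain than that of compound 4 would hold this low number or let it rise again remains open, as does what a branched chain, or a chain ending in an amine or a carboxylic acid, would give. With a single concentration per compound, the series also leaves open how the chains compare in potency.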